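Swapping the triazole nitrogen substituent in a chromene ester

This account rests on a few compounds, and the source may have more. Where it says the series, first, only, none or still open, it means among the compounds named here.

Compound 1, `CCOC(=O)C1=Cc2ccccc2OC1(OCc1cn(CC(=O)Nc2cccc(Cl)c2)nn1)C(F)(F)F`, in a functional assay on MCF7 cells (Homo sapiens) for inhibition, read by MTT assay, with a stated time of 24 h; a lower number here means a stronger inhibitor, a higher number a weaker inhibitor: 11600 nM
Compound 2, `O=C(O)C1=Cc2ccccc2OC1(OCc1cc(-c2ccc([N+](=O)[O-])cc2)no1)C(F)(F)F`, in this assay: a limit, > 150000 nM

Going by the values given here, only one number is known here. In this assay, among the compounds with values here, compound 1 gives 11600 nM, and that is the sole measured value. Compound 2 is reported only as a limit of the assay, (the limit of > 150000 nM in this assay, at which 1 of the 2 values shown sits), so no number stands beside it. Compound 2 differs from compound 1 in more than one place. Within the data shown here, no single step between the two measured compounds can be read.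

Compound 3, `CCOC(=O)C1=Cc2ccccc2OC1(OCc1cn(-c2cccc(C(F)(F)F)c2)nn1)C(F)(F)F`, has not yet been measured. It keeps the core of compound 1 and changes one group: 3-(trifluoromethyl)phenyl in place of ((3-chlorophenyl)carbamoyl)methyl on an aromatic nitrogen. Among the measured compounds shown here, nothing measured here tells how such a swap moves the read-out, so the expectation rests on the one known value of compound 1 alone.

For compound 3 the estimate in this assay is 12000 nM, with a range from 4000 nM to 40000 nM. The step expected is a 1.0-fold higher number from compound 1 to compound 3 (0.01 log units; within the scatter), which is meant as no change beyond the usual scatter.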

Compound 3, half-maximal inhibitory concentration: > 150000 nM
Compound 3 ended at the assay's limit (the forecaster's own chance of this, stated with the estimate: 15%); middle value at least 12-fold (1.09 log units) from the limit.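

In this assay, the group on this aromatic nitrogen turns out to matter a great deal: 3-(trifluoromethyl)phenyl in place of ((3-chlorophenyl)carbamoyl)methyl gives an at least 12-fold higher number from compound 1 to compound 3 (1.11 log units; beyond the scatter). The result for compound 3 is a limit of the assay and not a number, so the step marks a minimum size, and compound 3 now shares that limit with compound 2: the limit of > 150000 nM in this assay, at which 2 of the 3 values shown sit. The leaving group carries a hydrogen-bond donor and a hydrogen-bond acceptor and the entering group carries neither, but this single step cannot separate that difference from the others between the two groups.

As far as these compounds go, whether the amide link or the substituent on the phenyl ring carries the effect stays open, and a ((3-(trifluoromethyl)phenyl)carbamoyl)methyl group on the same nitrogen would help to separate the two. Also open, from the compounds shown here alone, is how a simple amine or a carboxylic acid at the end of a short chain would behave here, and steps involving compound 2 cannot be read, as it differs from the other compounds in more than one place.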